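The source may report more compounds than this note shows. Statements on the series, on what has been measured and on what is new or still open speak of the compounds shown alone.

Compound 1 `COc1ccc(-c2c(C)nc3c(N4CC[C@@H](NC(C)=O)C4)cc(C)nn23)cc1OC` was tested in an ADME assay on microsomes from liver (Homo sapiens) for metabolic stability, read by LC-MS, with NADPH named in the record, with a stated time of 60 min, tested at 1 uM, in the absence of a further agent; a higher number here means that more of the compound is left, a lower number that less of the compound is left. In this assay compound 1 gives > 95%, which is a limit of the assay rather than a number. Compound 2 `CC(=O)N[C@@H]1CCN(c2cc(C)nn3c(-c4ccccc4)c(C)nc23)C1` carries phenyl in place of 3,4-dimethoxyphenyl on an aromatic carbon; in this assay compound 2 gives > 95%, also a limit. Compound 3 `CC(=O)N[C@@H]1CCN(c2cc(C)nn3c(-c4nccs4)c(C)nc23)C1` carries 1,3-thiazol-2-yl in place of 3,4-dimethoxyphenyl on an aromatic carbon; in this assay compound 3 gives > 95%, again a limit. Because (the limit of > 95% in this assay, at which 3 of the 3 values shown sit), the steps a step that the two limits leave unreadable from compound 1 to compound 2, a step that the two limits leave unreadable from compound 1 to compound 3 and a step that the two limits leave unreadable from compound 2 to compound 3 cannot be sized. Compound 4 `COc1ccc(-c2c(C)nc3c(N4CC[C@@H](NC(=O)OC5CCCCC5)C4)cc(C)nn23)cc1OC` differs from compound 1 at another place: cyclohexyloxy in place of methyl on a carbonyl carbon. Among the measured compounds shown here, none of the measured steps touches the carbonyl carbon, so no measured step bears on this change, and neither its size nor its direction can be read from the data. Compound 4 is estimated at 70% in this assay, with an expected range from 30% to 95%, meaning an expected step of a number at least 25 percentage points lower from compound 1 to compound 4 (beyond the scatter).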

Compound 4, percent of the compound remaining: > 95%
Compound 4 gave a limit, no number (the forecaster's own chance of this, stated with the estimate: 35%); at least 25 percentage points between middle value and limit.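

Compound 1 and compound 4 both stand at a limit rather than a number, so no step between them can be read: the limit of > 95% in this assay, at which 4 of the 4 values shown sit.

The compounds shown leave open whether cyclohexyloxy in place of methyl on the carbonyl carbon changes the amount remaining in this assay at all, and by how much.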